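The source may hold more compounds than are shown below. What is called first, only, known or untested is meant among the compounds shown, and "the series" means these compounds.

Compound 1 `CCCC(CCC)n1c(-c2ccc(OCc3c(-c4c(Cl)cccc4Cl)noc3C(C)C)cc2)nc2ccc(C(=O)O)cc21` was tested in an assay on HEK-293T cells for antagonist activity at vitamin D3 receptor (Homo sapiens), read by a luciferase reporter, with a stated time of 24 h (on this read-out higher numbers stand for weaker inhibition and lower numbers for stronger inhibition), where it gave only a limit, > 10000 nM. Its partner compound 2 `CC(C)c1onc(-c2c(Cl)cccc2Cl)c1COc1ccc(-c2nc3ccc(C(=O)O)cc3n2CC2CC2)cc1` is the one member of the pair with a numbered result: in this assay compound 2 gives 2650 nM, and this is the only number shown, so compound 2 stands as the single fixed point here. The move was an at least 3.7-fold lower number from compound 1 to compound 2 (0.57 log units; beyond the scatter), a change on the aromatic nitrogen of the shared core. Compound 3 `CC(C)c1onc(-c2c(Cl)cccc2Cl)c1COc1ccc(-c2nc3ccc(C(=O)O)cc3n2C2CCCCCC2)cc1` differs from compound 2 at that same nitrogen: cycloheptyl in place of cyclopropylmethyl on an aromatic nitrogen. Among the measured compounds shown here, the one measured step that bears on this change is an at least 3.7-fold lower number from compound 1 to compound 2 (0.57 log units; beyond the scatter), in which the group on the nitrogen was exchanged for the three-membered ring carrier and the number came down. Compound 3 now takes up a seven-membered ring in that place, a move in the other direction, so a step back toward the higher numbers, and possibly toward the limit again, is expected in this assay. Compound 3 is therefore estimated to give 7000 nM, within a range of 2500 nM to 20000 nM. The expected step is a 2.6-fold higher number from compound 2 to compound 3 (0.42 log units; beyond the scatter).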

Compound 3, half-maximal inhibitory concentration: 921 nM
Beside the measured number, compound 3's estimate is 7.6-fold (0.88 log units) above it; measured number outside the range, below it.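

In this assay, replacing cyclopropylmethyl, with 4 heavy atoms, by cycloheptyl, with 7, gives a 2.9-fold lower number from compound 2 to compound 3 (0.46 log units; beyond the scatter), so on this aromatic nitrogen a group with more heavy atoms can go with a lower number. The earlier step from 1-propylbutyl to cyclopropylmethyl had left open a simple reading in which a smaller group gives the lower number, but the exchange of 1-propylbutyl for cycloheptyl gives an at least 10-fold lower number from compound 1 to compound 3 (1.03 log units; beyond the scatter), showing that the open chain and the seven-membered ring are far apart at this place. The value of compound 1 is a limit and not a number, so this last step has no upper end: the limit of > 10000 nM in this assay, at which 1 of the 3 values shown sits.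

The three groups shown do not tell whether the numbers fall further or rise again with a cyclopentyl or cyclohexyl ring, or with a straight butyl chain, on this nitrogen. They also leave open how a ring carrying an amine or a hydroxyl group would read in this assay.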